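Swapping Methyl for Nitro in Compound 4

The compounds below may be only part of what the source reports. "The series", "measured", "known", "first", "only" and "open" are said of these compounds alone.

Compound 3 `C/C(=C\c1cc(-c2ccc(C)cc2)cs1)C(N)=O` has, in a functional assay on A549 cells (Homo sapiens) for cytotoxicity, read by CCK-8 assay, with a stated time of 24 h (on this read-out higher numbers stand for weaker inhibition and lower numbers for stronger inhibition), only a limit, > 50000 nM. It thus stands at the floor of what this assay reports, a position recorded as the limit of > 50000 nM in this assay, at which 2 of the 3 values shown sit. The comparison compounds carry a different core. Compound 1 `C/C(=C\c1ccc(-c2ccc(C)cc2)o1)C(N)=O` in this assay likewise gives only a limit, > 50000 nM. Compound 2 `C/C(=C\c1ccc(-c2ccc(F)cc2)o1)C(N)=O` in this assay gives 1650 nM. Going by the values given here, that pair supplies the one measured step, an at least 30-fold lower number from compound 1 to compound 2 (1.48 log units; beyond the scatter), and it is large.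

Compound 4 `C/C(=C\c1cc(-c2ccc([N+](=O)[O-])cc2)cs1)C(N)=O` differs from compound 3 in one place: nitro in place of methyl on an aromatic carbon. Among the compounds with values here, no measured step replaces methyl with nitro, so the step from compound 1 to compound 2 is the only guide: it shows that exchanging the methyl on that aromatic carbon for another small substituent can lower the number well beyond the scatter. On this ground a lower number in this assay is expected for compound 4, estimated as an at least 8.3-fold lower number from compound 3 to compound 4 (0.92 log units; beyond the scatter), though with the starting point a limit the true size cannot be pinned down. Compound 4 is expected to give about 6000 nM in this assay, within 1200 nM to 40000 nM, with a real chance that only a limit is again reported.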

Compound 4, half-maximal inhibitory concentration: 3500 nM
Estimate against measurement, compound 4: 1.7-fold (0.23 log units) above; low and high end bracket the measured number.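

Going by these compounds alone, on the core that had so far given only a limit, exchanging methyl for nitro on an aromatic carbon, para to a large group, brings a measured number in this assay: an at least 14-fold lower number from compound 3 to compound 4 (1.15 log units; beyond the scatter), a large step. Set beside an at least 30-fold lower number from compound 1 to compound 2 (1.48 log units; beyond the scatter), this shows that among the compounds shown, the departure of this methyl is followed by a step beyond the scatter on both cores and with two different entering groups, and no compound shown goes against that. The new step has only a lower bound, because compound 3 is reported as a limit and not as a number: the limit of > 50000 nM in this assay, at which 2 of the 4 values shown sit.

Fluoro and nitro stand on different cores here, so what the compounds shown cannot tell is whether one of these two groups does more than the other on the same core, and a fluoro analogue of compound 4 would be needed to read that directly. Also open, on these data alone, is whether the exchange of methyl at this place works for any other group, such as an amine, a carboxylic acid or a methoxy group, or only for the two seen so far.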